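Methoxy addition on the ketone-side aryl of compound 2

This account rests on a few compounds, and the source may have more. Where it says the series, first, only, none or still open, it means among the compounds named here.

Two members of this series have been measured in a functional assay on DU-145 cells (Homo sapiens) for antiproliferative activity, read by MTT assay, with a stated time of 24 h; a higher number here means a weaker inhibitor, a lower number a stronger inhibitor. Compound 1 `COc1ccc(-c2cc(/C=C/C(=O)c3ccc(OC)c(OC)c3)nc3cc(-c4ccccc4)nn23)cc1` gives 16400 nM in this assay. Compound 2 `COc1ccc(C(=O)/C=C/c2cc(-c3ccc(OC)c(OC)c3)n3nc(-c4ccccc4)cc3n2)cc1` gives 14600 nM in this assay. The two numbers lie within the scatter of each other, so neither compound stands apart from the other on the evidence so far; both sit in the same weak range.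

Compound 3 `COc1ccc(C(=O)/C=C/c2cc(-c3ccc(OC)c(OC)c3)n3nc(-c4ccccc4)cc3n2)cc1OC` has not been measured in this assay. It differs from compound 2 by methoxy in place of hydrogen on an aromatic carbon. No comparable step is available among the measured compounds, so nothing shown here supports a shift beyond the scatter in either direction; the expectation is that the number stays close to that of compound 2. The step from compound 2 to compound 3 is expected to be a 1.2-fold lower number from compound 2 to compound 3 (0.09 log units; within the scatter). For compound 3 the estimate in this assay is 12000 nM, with a range from 5000 nM to 30000 nM.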

Compound 3, half-maximal inhibitory concentration: 7200 nM
Compound 3: middle estimate off by 1.7-fold (0.22 log units), on the high side; low and high end bracket the measured number.
By their numbers in this assay, from the lowest: compound 3; then compounds 2 and 1 (each within the scatter of the next).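

In this assay, within the data shown here, going from (4-methoxyphenyl)carbonyl to (3,4-dimethoxyphenyl)carbonyl gives a 2.0-fold lower number from compound 2 to compound 3 (0.31 log units; beyond the scatter) and is the first change to clear the scatter, if only modestly. Methoxy in place of hydrogen on the other aryl group gives a 2.3-fold lower number from compound 1 to compound 3 (0.36 log units; beyond the scatter) and ends at the same compound, so among these three compounds, the lowest number goes with 3,4-dimethoxyphenyl on both aryl groups rather than on one. The data shown offer no measurement that would account for this shift.

Going by these compounds, it remains open whether the shift is specific to methoxy, or whether ethoxy, hydroxy or fluorine at the same carbon would give a similar number. Also open, on these data alone, is where a compound with 4-methoxyphenyl on both aryl groups would fall, which would show whether a single added methoxy moves the number from that starting point.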